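Two fluorines on the sulfonyl ring: a cytotoxicity estimate

A few compounds are considered here, and "the series" means these few. Any claim that something is new, unique, unknown or untested is made for them only; others in the source may bear on it.

Measured compounds:
- Compound 1, `CC1(Cc2ccccc2)CC(S(=O)(=O)c2ccccc2F)=C(c2ccc(/C(N)=N\O)cc2)O1`: 29100 nM
- Compound 2, `CC1(Cc2ccccc2)CC(S(=O)(=O)c2cccc(F)c2)=C(c2ccc(/C(N)=N\O)cc2)O1`: 28300 nM
- Compound 3, `N/C(=N/O)c1ccc(C2=C(S(=O)(=O)c3ccc(F)cc3)CC(c3ccccc3)(c3ccccc3)O2)cc1`: 10200 nM

These three compounds share a core and were tested in an ADME assay on J774.A1 cells (Mus musculus) for cytotoxicity, read by MTT assay, with a stated time of 72 h; on this read-out lower numbers stand for higher toxicity in this test and higher numbers for lower toxicity in this test. Compound 2 gives 28300 nM, the second highest of the three numbers. Its nearest neighbour is compound 1, and the step of a 1.0-fold lower number from compound 1 to compound 2 (0.01 log units; within the scatter) lies within the scatter, so the two cannot be told apart. Compound 3 gives 10200 nM, a lower number that lies beyond the scatter, but compound 3 differs from compound 2 in more than one place, so no single change can be read from it.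

The new compound 4, `CC1(Cc2ccccc2)CC(S(=O)(=O)c2ccc(F)cc2F)=C(c2ccc(/C(N)=N\O)cc2)O1`, differs from compound 2 by 2,4-difluorophenyl in place of 3-fluorophenyl on a sulfonyl sulfur. Within the data shown here, the only step that bears on the group on the sulfonyl sulfur is a 1.0-fold lower number from compound 1 to compound 2 (0.01 log units; within the scatter), which moved the single fluorine and changed nothing beyond the scatter. Among the measured compounds shown here, no measured step adds a second fluorine. For the measured compounds named here, with only that evidence, no step beyond the scatter is expected in this assay, and the estimated step is a 1.0-fold lower number from compound 2 to compound 4 (0.00 log units; within the scatter). Compound 4 is therefore expected to give about 28000 nM, within a range from 14000 nM to 56000 nM.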

Compound 4, half-maximal cytotoxic concentration: 41500 nM
The estimate for compound 4 lay 1.5-fold (0.17 log units) below the measured number; low and high end bracket the measured number.
By their numbers in this assay, from the lowest: compound 3; then compounds 2, 1 and 4 (each within the scatter of the next).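

Adding a second fluorine to the ring on the sulfonyl sulfur is a change the earlier compounds did not cover, and in this assay it gives a 1.5-fold higher number from compound 2 to compound 4 (0.17 log units; within the scatter) when 2,4-difluorophenyl replaces 3-fluorophenyl, and a 1.4-fold higher number from compound 1 to compound 4 (0.15 log units; within the scatter) when fluoro replaces hydrogen on an aromatic carbon. Compound 1, compound 2 and compound 4 differ only in the fluorines on this ring, and neither their number nor their placing has produced a difference that this test can resolve. Nothing measured here offers an explanation for this flat picture.

As far as these compounds go, whether the position stays this undemanding with something other than a fluorinated phenyl ring on the sulfonyl sulfur, such as an amine, a carboxylic acid or a longer chain, remains open. Compound 3 differs from the others in more than one place, so its number cannot be read as the result of any single change.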